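The compounds below may be only part of what the source reports. "The series", "measured", "known", "first", "only" and "open" are said of these compounds alone.

Compound 1 `Cc1cc(=O)oc2c1c(C)nn2CCO` was tested in a functional assay on the whole organism with Mus musculus as the target, in the writhing test (on this read-out higher numbers stand for an effect only at larger amounts of compound and lower numbers for an effect already at smaller amounts), where compound 1 gives 100 mg/kg. Compound 2 `CCN(CC)CCn1nc2oc(=O)cc(C)c2c1C`, which carries a longer amine-bearing chain on the same core, gives 100 mg/kg in this assay. The two values are level at the digits shown, and the gap between them lies within the scatter of repeated measurements, so nothing separates compound 1 from compound 2 on this read-out. Compound 3 `CCCCn1nc(C)c2c(C)cc(=O)oc21` has not yet been measured. It differs from compound 1 in one place: ethyl in place of hydroxy on a saturated chain carbon, two bonds along the chain from an aromatic nitrogen. Compound 3 therefore carries a butyl chain where compound 1 carries a 2-hydroxyethyl chain. Going by the values given here, no measured pair shows what this kind of change does, and the two values in hand give no sign that the chain on the aromatic nitrogen shifts the dose either way. The change is expected to move the dose by no change at the digits printed from compound 1 to compound 3 (within the scatter), which is no more than the scatter. Compound 3 is estimated to give 100 mg/kg in this assay, with a range from 40 mg/kg to 250 mg/kg.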

Compound 3, dose for half-maximal effect: > 100 mg/kg
Compound 3 gave a limit, no number (the forecaster's own chance of this, stated with the estimate: 20%); the middle value lies on the limit itself.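

In this assay compound 3 gives > 100 mg/kg, which is a limit of the assay and not a number. Read as a step, the change is a number no lower from compound 1 to compound 3 (the limit leaves the size open), so this is the first direct look at this place on the chain: ethyl in place of hydroxy, on a saturated chain carbon, two bonds along the chain from an aromatic nitrogen, does not bring the effect down to smaller amounts of compound, and swapping the 2-hydroxyethyl chain for butyl gives no gain on this read-out, although how much is lost, if anything, cannot be told. All of this rests on a single reading that gives a direction only: the limit of > 100 mg/kg in this assay, at which 1 of the 3 values shown sits.

On these data alone, it stays open how far beyond the limit compound 3 really lies, and so whether the hydroxy group matters at all in this assay or the two chains simply perform alike. As far as these compounds go, it also stays open whether a methoxy group or a carboxylic acid at this place on the chain would let the effect appear at smaller amounts of compound.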